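Cytotoxicity series: arylidene succinimides with benzamide side chain

The source may report more compounds than this note shows. Statements on the series, on what has been measured and on what is new or still open speak of the compounds shown alone.

Measured compounds, in an ADME assay on NCM460 cells (Homo sapiens) for cytotoxicity, read by MTT assay, with a stated time of 72 h; on this read-out higher numbers stand for weaker inhibition and lower numbers for stronger inhibition:
- compound 1 `Cc1ccc(N2C(=O)C/C(=C\c3cccc(C(=O)Nc4cccc(F)c4)c3)C2=O)cc1` gives > 100000 nM, a limit of the assay.
- compound 2 `Cc1ccc(NC(=O)c2cccc(/C=C3\CC(=O)N(c4ccccc4)C3=O)c2)cc1C` gives > 100000 nM, a limit of the assay.
- compound 3 `Cc1ccc(N2C(=O)C/C(=C\c3cccc(C(=O)Nc4ccc(Cl)cc4)c3)C2=O)cc1` gives > 100000 nM, a limit of the assay.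

Compound 2 stands only at a limit in this assay; the two further values shown are likewise limits, so no ranking among the three is possible.

Going by the values given here, the only step between measured compounds that differ in one place is a step that the two limits leave unreadable from compound 1 to compound 3, 4-chlorophenyl in place of 3-fluorophenyl on an amide-type nitrogen. Both ends are limits, so its size cannot be read, and the shared position of all values at the limit of > 100000 nM in this assay, at which 3 of the 3 values shown sit, gives no hold for any direction.

Compound 4 `O=C(NCc1ccccc1)c1cccc(/C=C2\CC(=O)N(c3ccccc3)C2=O)c1` differs from compound 2 by benzyl in place of 3,4-dimethylphenyl on an amide-type nitrogen; cut one bond further out, (3,4-dimethylphenyl)amino becomes benzylamino. Among the compounds with values here, no measured step bears on this change. With every value in the series at a limit, the step from compound 2 to compound 4 is expected to be a step that the limit leaves unreadable from compound 2 to compound 4, none beyond the scatter, and compound 4 is estimated at 150000 nM in this assay, in a range from 40000 nM to 500000 nM, most likely reported again as a limit.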

Compound 4, half-maximal inhibitory concentration: > 100000 nM
Compound 4 ended at the assay's limit; the forecaster's own chance of this, stated with the estimate: 80%; the middle value lies beyond the limit too.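

In this assay compound 4 gives > 100000 nM, a limit of the assay. No step can be read between compound 2 and compound 4, since both stand at a limit: the limit of > 100000 nM in this assay, at which 4 of the 4 values shown sit.

The compounds shown leave open which change, if any, would bring a value within the readable range of this read-out.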